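The compounds below may be only part of what the source reports. "The series", "measured", "known", "first", "only" and "open" are said of these compounds alone.

In a functional assay on HBL-100 cells (Homo sapiens) for antiproliferative activity, read by MTT assay, with a stated time of 72 h (on this read-out higher numbers stand for weaker inhibition and lower numbers for stronger inhibition), three compounds that share one core have been measured. Compound 1 `Cc1ccc(/C=N/NC(=S)N2CCNCC2)cc1` gives 800 nM; compound 2 `S=C(N/N=C/c1ccccc1)N1CCNCC1` gives 2410 nM; and compound 3 `COc1ccc(/C=N/NC(=S)N2CCNCC2)cc1` gives 1620 nM. Compound 3 thus stands second highest of the three numbers: it lies nearest to compound 2, within the scatter of it, and furthest from compound 1, which sits beyond the scatter below it.

Compound 4 `Oc1ccc(/C=N/NC(=S)N2CCNCC2)cc1` differs from compound 3 in one place: hydrogen in place of methyl on an oxygen on an aromatic ring, so that the methoxy becomes a hydroxy. The steps measured so far all concern the substituent on that aromatic carbon. The step of a 3.0-fold higher number from compound 1 to compound 2 (0.48 log units; beyond the scatter) and the step of a 2.0-fold higher number from compound 1 to compound 3 (0.31 log units; beyond the scatter) were both modest, while the step of a 1.5-fold lower number from compound 2 to compound 3 (0.17 log units; within the scatter) fell within the scatter. Changes at this position have therefore moved this assay by only modest amounts in either direction, and the swap from methoxy to hydroxy is smaller in count than any of them.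

Compound 4 is accordingly expected to sit close to compound 3, with a step of a 1.1-fold higher number from compound 3 to compound 4 (0.05 log units; within the scatter) that is not expected to exceed the scatter. The estimate for compound 4 in this assay is 1800 nM, with a range from 800 nM to 4000 nM.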

Compound 4, half-maximal inhibitory concentration: 180 nM
For compound 4 the middle estimate is 10-fold (1.00 log units) above the measured one, outside the stated range (below it).
By their numbers in this assay, from the lowest: compound 4; then compound 1; then compounds 3 and 2 (each within the scatter of the next).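

In this assay, taking the methyl off the oxygen on the aromatic ring gives a 9.0-fold lower number from compound 3 to compound 4 (0.95 log units; beyond the scatter) and so moves the number further than any step among compound 1, compound 2 and compound 3 had, which shows that this position is far more sensitive than those compounds suggested. Hydroxy also stands apart from the other two groups on this aromatic carbon, with a 13-fold lower number from compound 2 to compound 4 (1.13 log units; beyond the scatter) when it replaces hydrogen and a 4.4-fold lower number from compound 1 to compound 4 (0.65 log units; beyond the scatter) when it replaces methyl, so that compound 4 is the most potent of the four and the oxygen alone does not account for the gain, as compound 3 carries an oxygen there and stays within the scatter of compound 2. Nothing available here explains why this one small change counts for so much.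

The compounds shown leave open whether the low number is peculiar to hydroxy or would also come with an amine or a carboxylic acid on that aromatic carbon. They also leave open whether a longer chain on the oxygen, such as ethoxy, would stay near compound 3.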